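Halogen Swap on the Sulfonamide: Expecting Compound 4

The source may hold more compounds than are shown below. What is called first, only, known or untested is meant among the compounds shown, and "the series" means these compounds.

Compound 1 `CN(C(=O)c1ccc(Cl)cc1)c1ccc2[nH]c(-c3n[nH]c4ccccc34)cc2n1`: 2420 nM
Compound 2 `CN(C(=O)c1ccc(Br)cc1)c1ccc2[nH]c(-c3n[nH]c4ccccc34)cc2n1`: 3460 nM
Compound 3 `CN(c1ccc2[nH]c(-c3n[nH]c4ccccc34)cc2n1)S(=O)(=O)c1ccc(Cl)cc1`: 12700 nM

These three compounds were measured in a functional assay on SMMC-7721 cells (Homo sapiens) for antiproliferative activity, read by MTT assay, with a stated time of 72 h; on this read-out higher numbers stand for weaker inhibition and lower numbers for stronger inhibition. Compound 1 and compound 2 differ by bromo in place of chloro on an aromatic carbon, and this change produced a 1.4-fold higher number from compound 1 to compound 2 (0.16 log units; within the scatter). The cores of compound 1 and compound 3 differ by (4-chlorophenyl)sulfonyl in place of (4-chlorophenyl)carbonyl on a nitrogen on an aromatic ring, a change that produced a 5.2-fold higher number from compound 1 to compound 3 (0.72 log units; beyond the scatter), and likewise a 3.7-fold higher number from compound 2 to compound 3 (0.56 log units; beyond the scatter). Compound 4 `CN(c1ccc2[nH]c(-c3n[nH]c4ccccc34)cc2n1)S(=O)(=O)c1ccc(Br)cc1` has not yet been measured in this assay. It differs from compound 3 by bromo in place of chloro on an aromatic carbon, the same change as that from compound 1 to compound 2, at a place described in identical words. Since the earlier step of a 1.4-fold higher number from compound 1 to compound 2 (0.16 log units; within the scatter) stayed within the scatter, a step of similar size is anticipated here. Compound 4 is therefore expected to show a 1.3-fold higher number from compound 3 to compound 4 (0.10 log units; within the scatter) in this assay. The estimate for compound 4 is 16000 nM, between 7000 nM and 36000 nM.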

Compound 4, half-maximal inhibitory concentration: 11500 nM
For compound 4 the middle estimate is 1.4-fold (0.14 log units) above the measured one; measured number inside the range.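

In this assay, bromo in place of chloro gave a 1.1-fold lower number from compound 3 to compound 4 (0.04 log units; within the scatter), and this step and the earlier one on the carbonyl core cannot be told apart: the same change on two cores in this assay, a 1.4-fold higher number (0.16 log units; within the scatter) from compound 1 to compound 2 and a 1.1-fold lower number (0.04 log units; within the scatter) from compound 3 to compound 4, 1.6-fold (0.20 log units) apart, within the scatter of two such steps. With bromo on the ring, the exchange of carbonyl for sulfonyl still gave a 3.3-fold higher number from compound 2 to compound 4 (0.52 log units; beyond the scatter), while the step that also exchanges the halogen gave a 4.8-fold higher number from compound 1 to compound 4 (0.68 log units; beyond the scatter). This shows that the halogen swap carried over between these two cores with no step beyond the scatter, but it does not show that it would do so on any other core or in any other assay.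

The compounds shown carry only chloro or bromo at this place, so an amine, a methoxy group or a carboxylic acid there remains open. Also open, from the compounds shown here alone, is a longer chain in place of the methyl on the nitrogen.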